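Azetidinyl to pyrrolidinyl on the shared core

The compounds below may be only part of what the source reports. "The series", "measured", "known", "first", "only" and "open" are said of these compounds alone.

Measured compounds in a functional assay on ECa-109 cells for inhibition, with ECa-109 cell line (Homo sapiens) as the target, read by sulforhodamine B assay; on this read-out higher numbers stand for weaker inhibition and lower numbers for stronger inhibition:
- compound 1 `O=C1C=C(N2CCC2)C(=O)c2c1nc1n2[C@H]2OC[C@@H](O)[C@H]2OC1`: compound 1 gives > 16000 nM, a limit of the assay.
- compound 2 `O=C1C(NC2CCCC2)=CC(=O)c2c1nc1n2[C@H]2OC[C@@H](O)[C@H]2OC1`: compound 2 gives > 16000 nM, a limit of the assay.
- compound 3 `O=C1C(N2CCCC2)=CC(=O)c2c1nc1n2[C@H]2OC[C@@H](O)[C@H]2OC1`: compound 3 gives > 16000 nM, a limit of the assay.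

Compound 1 stands at a limit only, and the two further values shown are limits as well, so no ordering among the three can be read; all sit at the limit of > 16000 nM in this assay, at which 3 of the 3 values shown sit.

For the measured compounds named here, the one step between measured compounds is a step that the two limits leave unreadable from compound 2 to compound 3, and the two limits leave its size unreadable.

Compound 4 `O=C1C=C(N2CCCC2)C(=O)c2c1nc1n2[C@H]2OC[C@@H](O)[C@H]2OC1` differs from compound 1 by pyrrolidin-1-yl in place of azetidin-1-yl on a double-bonded ring carbon. Going by the values given here, no measured step bears directly on this change. Compound 3 carries the same pyrrolidin-1-yl group and also sits at the limit, and compound 1 itself sits at the limit, so nothing shown points to inhibition strong enough to yield a number for compound 4.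

The expected step for compound 4 in this assay is therefore a step that the limit leaves unreadable from compound 1 to compound 4, with no change beyond the scatter expected. Compound 4 is estimated at 20000 nM, within 8000 nM to 60000 nM, and most likely reported again as a limit.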

Compound 4, half-maximal inhibitory concentration: > 16000 nM
Compound 4 was reported as a limit; the forecaster's own chance of this, stated with the estimate: 75%; the middle value is on the limit's open side.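

In this assay compound 4 gives > 16000 nM, a limit of the assay. Compound 1 is also a limit, so no step can be read for pyrrolidin-1-yl in place of azetidin-1-yl: the limit of > 16000 nM in this assay, at which 4 of the 4 values shown sit.

The compounds shown leave open any ordering among them and whether any group at these places on the shared core gives a numeric value in this assay.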